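Pyrazoline Amides in a Prostate Cancer Cell Assay

The compounds below may be only part of what the source reports. "The series", "measured", "known", "first", "only" and "open" are said of these compounds alone.

Compound 1: `CC1=NN(S(=O)(=O)c2ccc([N+](=O)[O-])cc2)C(c2cc(Cl)ccc2O)C1` gives 44200 nM in a functional assay on PC-3 cells (Homo sapiens) for cytotoxicity, read by MTT assay, with a stated time of 48 h; on this read-out lower numbers stand for stronger inhibition and higher numbers for weaker inhibition.
Compound 2: `O=C(c1ccccc1Cl)N1N=C(c2cc3ccccc3oc2=O)CC1c1ccccc1` gives 6370 nM in this assay.

Compound 2 has the lowest number of the two measured, and compound 1 sits clearly above it, beyond the usual scatter. Compound 3, `O=C(CNC1CC1)N1N=C(c2cc3ccccc3oc2=O)CC1c1ccccc1`, carries the change ((cyclopropylamino)methyl in place of 2-chlorophenyl on a carbonyl carbon). Among the measured compounds shown here, no measured pair shows this kind of exchange, so its effect is uncertain. A modest rise in the number, beyond the scatter, is expected, giving an estimated step of a 1.9-fold higher number from compound 2 to compound 3 (0.28 log units; within the scatter). Compound 3 is therefore expected to give about 12000 nM in this assay, with a likely range from 3000 nM to 45000 nM.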

Compound 3, half-maximal inhibitory concentration: 28500 nM
For compound 3 the middle estimate is 2.4-fold (0.38 log units) below the measured one; the range from low to high includes it.
By their numbers in this assay, from the lowest: compound 2; then compounds 3 and 1 (each within the scatter of the next).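

On the carbonyl carbon of the shared core, replacing 2-chlorophenyl with (cyclopropylamino)methyl gives a 4.5-fold higher number from compound 2 to compound 3 (0.65 log units; beyond the scatter) in this assay, so the group at this position affects the read-out. The exchange removes an aromatic ring and its chlorine and brings in a three-membered ring with a hydrogen-bond donor and acceptor, and this single pair cannot separate those differences. No available measurement explains the step. From the compounds shown here alone, it remains open whether a plain phenyl without the chlorine, or a dimethylaminomethyl group, on the same carbonyl carbon would give a number closer to that of compound 2.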